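The compounds below may be only part of what the source reports. "The series", "measured", "known", "first", "only" and "open" are said of these compounds alone.

Measured so far in an in vitro ADME assay on microsomes from liver (Homo sapiens) for metabolic stability; a lower number here means slower removal, a higher number faster removal of the compound:
- Compound 1 `Cc1cnc(NC(=O)c2cc(Oc3ccc(S(C)(=O)=O)cc3)c3cn(C)nc3c2)cn1`: < 8 mL/min/kg (a limit)
- Compound 2 `Cc1cnc(NC(=O)c2cc(Oc3ccc(S(C)(=O)=O)cc3)c3cn(CCO)nc3c2)cn1`: < 8.9 mL/min/kg (a limit)

In this assay compound 2 stands at < 8.9 mL/min/kg, which is a limit and not a number. Compound 1 likewise gives only a limit, < 8 mL/min/kg. Within the data shown here, the one measured step is a step that the two limits leave unreadable from compound 1 to compound 2, so the series offers no readable step size.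

Compound 3 `Cc1cnc(NC(=O)c2cc(Oc3ccc(S(C)(=O)=O)cc3)c3cn(C4CC4)nc3c2)cn1` carries cyclopropyl in place of 2-hydroxyethyl on an aromatic nitrogen. Among the measured compounds shown here, no measured step covers this exchange directly. The closest evidence is the change on the same nitrogen from compound 1 to compound 2, where both compounds remain limits. No step beyond the scatter is therefore expected, in either direction, and a further limit is likely. The expected change is a step that the limit leaves unreadable from compound 2 to compound 3. For compound 3 the estimated clearance is 8 mL/min/kg, with an expected range of 5 mL/min/kg to 16 mL/min/kg.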

Compound 3, clearance: < 8 mL/min/kg
Compound 3 gave a limit, no number; the forecaster's own chance of this, stated with the estimate: 65%; the middle value lies on the limit itself.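

In this assay, among these compounds, compound 1, compound 2 and compound 3 each give only a limit, so no step between them can be read. Still open, from the compounds shown here alone, is whether methyl, 2-hydroxyethyl and cyclopropyl on the aromatic nitrogen differ at all in clearance.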